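Thiophen-2-yl in place of pyridin-3-yl on the alkyne

A few compounds are considered here, and "the series" means these few. Any claim that something is new, unique, unknown or untested is made for them only; others in the source may bear on it.

Compound 1, `O=C1c2ccc(C#Cc3ccc(Cl)cc3)nc2CCN1C1CCCC1`, in an assay on HEK293 cells for displacement of a labelled ligand from metabotropic glutamate receptor 5 (Homo sapiens), with a stated time of 2 h; on this read-out higher numbers stand for weaker inhibition and lower numbers for stronger inhibition: > 32000 nM, a limit of the assay.
Compound 2, `O=C1c2ccc(C#Cc3cccnc3)nc2CCN1C1CCCC1`, in this assay: > 32000 nM, a limit of the assay.

Compound 2 stands at the limit of this assay, with no number beyond it. Compound 1 likewise sits at a limit. The step that the two limits leave unreadable from compound 1 to compound 2 is therefore unreadable, and both values shown sit at the limit of > 32000 nM in this assay, at which 2 of the 2 values shown sit. Compound 3, `O=C1c2ccc(C#Cc3cccs3)nc2CCN1C1CCCC1`, differs from compound 2 by thiophen-2-yl in place of pyridin-3-yl on a triple-bonded carbon. Among the measured compounds shown here, no measured step gives a readable size for this kind of change; the single step available is the unreadable one from compound 1 to compound 2. With both neighbours at the limit, the most likely outcome for compound 3 is again a reading at the limit, and any step beyond the scatter cannot be foreseen from what is shown. The expected step is a number no higher from compound 2 to compound 3 (the limit leaves the size open). Compound 3 is estimated at 32000 nM, with a range from 8000 nM to 100000 nM.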

Compound 3, inhibition constant: 2840 nM
Compound 3: middle estimate off by 11-fold (1.05 log units), on the high side; the whole stated range lies above it.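

The group on the triple-bonded carbon can therefore move this read-out: in this assay, thiophen-2-yl gives an at least 11-fold lower number from compound 2 to compound 3 (1.05 log units; beyond the scatter), and the same group in place of 4-chlorophenyl gives an at least 11-fold lower number from compound 1 to compound 3 (1.05 log units; beyond the scatter). Both steps start from a limit, so each gives only the smallest size the step can have, while the step between compound 1 and compound 2 cannot be read. Compound 3 is the only one of the three with a number rather than a limit: the limit of > 32000 nM in this assay, at which 2 of the 3 values shown sit.

The compounds shown leave open whether this effect belongs to thiophen-2-yl alone or extends to another five-membered aromatic ring, such as furan-2-yl or thiazol-2-yl, on the same carbon. They also leave open how thiophen-2-yl would read with cyclohexyl in place of the cyclopentyl group of the shared core.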